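This account rests on a few compounds, and the source may have more. Where it says the series, first, only, none or still open, it means among the compounds named here.

Measured in a functional assay on BJAB cells (Homo sapiens) for antiproliferative activity, with a stated time of 4 days; a higher number here means that more compound is needed for the effect, a lower number that less compound is needed:

Compound 1 `CCSc1sc(-n2nc(C)c(Cc3ccccc3[N+](=O)[O-])c2C(=O)O)nc1-c1ccc(Cl)c(Cl)c1` gives 59000 nM.
Compound 2 `Cc1c(-c2cc(Cl)cc(Cl)c2)c(C(=O)O)nn1-c1nc(-c2cc(Cl)ccc2F)c(SC(C)C)s1` gives 4800 nM.
Compound 3 `COc1ccc(-c2c(C)nn(-c3nc(-c4ccc(Cl)c(Cl)c4)c(SC(C)C)s3)c2C(=O)O)cc1` gives 2100 nM.

Of these three, compound 3 has the lowest number in this assay, so it needs the least compound to slow the growth of the cells. Compound 2 comes nearest, and its gap to compound 3 is beyond the usual scatter; compound 1 lies furthest away, with a gap far beyond the scatter. Since no two of the measured compounds differ in only one place, none of these gaps can be tied to a single structural change.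

Compound 4 `Cc1nn(-c2nc(-c3ccc(Cl)c(Cl)c3)c(SC(C)C)s2)c(C(=O)O)c1-c1ccc(Cl)cc1` is the unmeasured compound. It differs from compound 3 in one place: chloro in place of methoxy on an aromatic carbon. Among the compounds with values here, nothing among the measured compounds isolates this particular swap, so its effect in this assay can only be guessed. The exchange of one small group for another on the outer ring is expected to move the number little, if at all, in either direction, most likely staying within the scatter. Compound 4 is therefore estimated at 2500 nM, with a plausible range from 800 nM to 8000 nM, which corresponds to an expected step of a 1.2-fold higher number from compound 3 to compound 4 (0.08 log units; within the scatter).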

Compound 4, half-maximal effective concentration: 2500 nM
Beside the measured number, compound 4's estimate shows no gap at the digits printed, and the stated range covers the measured number.
By their numbers in this assay, from the lowest: compounds 3, 4 and 2 (each within the scatter of the next, the first and the last beyond it); then compound 1.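

Going from 4-methoxyphenyl to 4-chlorophenyl in this assay gives a 1.2-fold higher number from compound 3 to compound 4 (0.08 log units; within the scatter), so compound 3 and compound 4 cannot be told apart in this measurement. Within the data shown here, this is the first pair here that differs in only one place, which means a single change can finally be read on its own: at this aromatic carbon, para to a large group, a methoxy with its two heavy atoms and one hydrogen-bond acceptor and a chloro with one heavy atom and no acceptor give the same result within the scatter. No measurement is available that would explain why the two groups behave alike in this assay.

This single pair cannot show whether the position accepts almost any group or only certain ones, and an amine, a hydroxyl group, a carboxylic acid or a longer chain such as butoxy in the same place could give a different result. It also leaves open whether a plain phenyl ring with no group at this carbon would match compound 3 and compound 4, and so whether a group is needed here at all.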